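Removing an amino link from a urea-like bridge

This account rests on a few compounds, and the source may have more. Where it says the series, first, only, none or still open, it means among the compounds named here.

Measured so far:
compound 1 `COc1cc(Cl)cc(-c2nn(-c3cccc(NC(=O)Nc4ccc(Cl)c(C(F)(F)F)c4)c3)cc2-c2ccncc2)c1`: -94%
compound 2 `COc1cc(Cl)cc(-c2nn(-c3cccc(NC(=O)Nc4cccc(C(F)(F)F)c4)c3)cc2-c2ccncc2)c1`: -81%

Both numbers come from a functional assay on HCT-116 cells (Homo sapiens) for inhibition, read by sulforhodamine B assay, with a stated time of 48 h, tested at 100 uM; on this read-out lower numbers stand for a stronger effect and higher numbers for a weaker effect at the one concentration tested. Compound 2 stands as the higher of the two, that is the weaker effect, and its nearest neighbour, compound 1, sits lower by a number 13 percentage points higher from compound 1 to compound 2 (beyond the scatter), a step that comes from putting hydrogen in place of chloro on an aromatic carbon and that lies beyond the scatter.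

Compound 3 `COc1cc(Cl)cc(-c2nn(-c3cccc(NC(=O)c4cccc(C(F)(F)F)c4)c3)cc2-c2ccncc2)c1` differs from compound 2 in a different place: 3-(trifluoromethyl)phenyl in place of (3-(trifluoromethyl)phenyl)amino on a carbonyl carbon. Within the data shown here, no measured pair shows this kind of change. Among the measured compounds shown here, the only step known, from compound 1 to compound 2, concerns a chloro on another ring and says nothing about removing the amino part of the bridge. For the measured compounds named here, with no comparable step to lean on, the expectation for this assay rests on compound 2 alone, and a step of a number 3 percentage points higher from compound 2 to compound 3 (within the scatter), within the scatter, is expected. Compound 3 is therefore estimated at -78%, with a range from -95% to -50%.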

Compound 3, a percentage reported as activity, at one concentration (the size of the read-out at that concentration, not a potency): 22%
Compound 3: the middle estimate sits 100 percentage points below what was measured; the measured number lies above the stated range.
By their numbers in this assay, from the lowest: compound 1; then compound 2; then compound 3.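

In this assay the amino link of the bridge carries far more weight than the chloro on the other ring: removing it gives a number 103 percentage points higher from compound 2 to compound 3 (beyond the scatter) and, starting from the chloro-bearing urea, a number 116 percentage points higher from compound 1 to compound 3 (beyond the scatter) while the loss of the chloro alone gave only a number 13 percentage points higher from compound 1 to compound 2 (beyond the scatter) in the earlier pair. The sign of the read-out also changes, since compound 2 stands at -81% and compound 3 at 22% on the same scale, so this change does more than shrink the effect at the one concentration tested. The group that leaves holds a nitrogen and a hydrogen-bond donor and the group that enters holds neither, but no measurement at hand explains why the number moves so far.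

Only one replacement of this link is shown, so it stays open whether the nitrogen, its hydrogen or the length of the bridge matters most. A methylene in place of the amino link, or a methylamino group that keeps the nitrogen but not its hydrogen, would help to tell these readings apart.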